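A few compounds are considered here, and "the series" means these few. Any claim that something is new, unique, unknown or untested is made for them only; others in the source may bear on it.

Measured compounds:
compound 1 `Cc1ccccc1CNC(=O)n1c(N)nc2ccccc21` — < 0.0834 h
compound 2 `O=C(NCCCCc1ccccc1)n1ncc2ccccc21` — > 2 h
compound 3 `Cc1nc2ccccc2n1C(=O)NCCCCc1ccccc1` — 0.183 h

In an ADME assay on a cell-free system (plasma, Mus musculus) for metabolic stability, read by HPLC, with a stated time of 120 min, tested at 2 uM (a higher number here means that the compound lasts longer, a lower number that the compound disappears faster), compound 3 is the only one of the three with a proper number, a half-life of 0.183 h. Compound 1 `Cc1ccccc1CNC(=O)n1c(N)nc2ccccc21` gives a limit, not a number: < 0.0834 h, which is the limit of < 0.0834 h in this assay, at which 1 of the 3 values shown sits. Compound 2 `O=C(NCCCCc1ccccc1)n1ncc2ccccc21` likewise gives a limit rather than a number: > 2 h, which is the limit of > 2 h in this assay, at which 1 of the 3 values shown sits. Among the compounds with values here, with only one firm number, no step between measured compounds can be stated, so compound 3 stands alone as the one fixed point in this assay.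

Compound 4 `O=C(NCCCCc1ccccc1)n1cnc2ccccc21` has not yet been tested in this assay. It differs from compound 3 in one place: hydrogen in place of methyl on an aromatic carbon. Within the data shown here, no measured pair shows what this change does, so the size of the step is open. Given that a single carbon leaves and nothing else moves, no step beyond the usual scatter of this assay is expected, in either direction. For compound 4 the half-life in this assay is estimated at 0.18 h, within 0.06 h to 0.6 h, a step of a 1.0-fold lower number from compound 3 to compound 4 (0.01 log units; within the scatter).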

Compound 4, half-life: > 2 h
Compound 4: no number, only a limit (the forecaster's own chance of this, stated with the estimate: 15%); at least 11-fold (1.04 log units) between middle value and limit.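

In this assay, the carbon between two ring nitrogen atoms proves sensitive to its substituent: hydrogen in place of methyl gives an at least 10-fold higher number from compound 3 to compound 4 (1.03 log units; beyond the scatter). Within the data shown here, no earlier pair had tested this position, and this step shows that the loss of a single carbon here can move the half-life well beyond the scatter. The value of compound 4 is a limit and not a number, so the step marks only the smallest size the change can have: the limit of > 2 h in this assay, at which 2 of the 4 values shown sit.

The compounds shown leave open whether a larger or different group at this carbon, such as ethyl or methoxy, would behave like the methyl of compound 3 or the hydrogen of compound 4. Going by these compounds, how long compound 4 actually lasts, and so the full size of the step, also remains open.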